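The compounds below may be only part of what the source reports. "The series", "measured", "known", "first", "only" and "open" are said of these compounds alone.

Measured so far in an assay on a protein complex for inhibition of NEDD8 activating enzyme (Homo sapiens), read by HTRF, with a stated time of 2 h, in the presence of a further agent that is not named here; a higher number here means a weaker inhibitor, a lower number a stronger inhibitor:
- compound 1 `NS(=O)(=O)OC[C@@H]1C[C@@H](n2nnc3c(NCc4ccco4)ncnc32)C[C@@H]1O`: 30.6 nM
- compound 2 `NS(=O)(=O)OC[C@@H]1C[C@@H](n2nnc3c(Nc4cnc5ccccn45)ncnc32)C[C@@H]1O`: > 10000 nM

The value for compound 2 in this assay is only a limit, and it sits at the limit of > 10000 nM in this assay, at which 1 of the 2 values shown sits. For the measured compounds named here, the one measured step, an at least 320-fold higher number from compound 1 to compound 2 (2.51 log units; beyond the scatter), is large.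

Compound 3 `NS(=O)(=O)OC[C@@H]1C[C@@H](n2nnc3c(N[C@@H]4c5ccccc5C[C@@H]4O)ncnc32)C[C@@H]1O` differs from compound 2 by a group of 10 heavy atoms (9 carbon, 1 oxygen; one five-membered non-aromatic ring of carbon only, one six-membered aromatic ring of carbon only) in place of a group of 9 heavy atoms (7 carbon, 2 nitrogen; one five-membered aromatic ring with 2 hetero atoms, one six-membered aromatic ring with 1 hetero atom), on a nitrogen on an aromatic ring. Going by the values given here, this change removes the group that accompanied the large loss in this assay and puts in a different substituent on the same nitrogen; no measured step covers the entering group, so its effect is inferred only from compound 1 and the step of an at least 320-fold higher number from compound 1 to compound 2 (2.51 log units; beyond the scatter). A large gain is expected, an at least 2000-fold lower number from compound 2 to compound 3 (3.30 log units; beyond the scatter). For compound 3 the estimate in this assay is 5 nM, in the range 0.5 nM to 50 nM.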

Compound 3, half-maximal inhibitory concentration: 2.28 nM
For compound 3 the middle estimate is 2.2-fold (0.34 log units) above the measured one, and the stated range covers the measured number.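

On the nitrogen on an aromatic ring, a group of 10 heavy atoms is tolerated and improves on the smaller group of compound 1: in this assay the change gives a 13-fold lower number from compound 1 to compound 3 (1.13 log units; beyond the scatter). Heavy-atom count alone therefore does not track the loss seen with compound 2, and this position spans an at least 4300-fold lower number from compound 2 to compound 3 (3.64 log units; beyond the scatter). That step rests on a limit for compound 2: the limit of > 10000 nM in this assay, at which 1 of the 3 values shown sits.

The compounds shown do not separate the contribution of the hydroxyl from that of the 2 defined stereocentres. Going by these compounds, whether an amine or a methoxy group could stand in place of the hydroxyl stays open.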